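A few compounds are considered here, and "the series" means these few. Any claim that something is new, unique, unknown or untested is made for them only; others in the source may bear on it.

Working notes on the series. Compound 1 `CN(Cc1ccc2nccn2c1)c1nnc(-c2ccccc2)o1` is the unsubstituted member. In an assay on isolated protein for inhibition of tyrosine-protein kinase receptor UFO (Homo sapiens), read by LC-MS (a lower number here means a stronger inhibitor, a higher number a weaker inhibitor), compound 1 gives > 100000 nM, which is a limit of the assay and not a number (the limit of > 100000 nM in this assay, at which 1 of the 3 values shown sits). Compound 2 `CN(Cc1ccc2nccn2c1)c1nnc(-c2ccc(-c3ccccc3)cc2)o1` carries a phenyl on the shared core; in this assay compound 2 gives 3160 nM. Compound 3 `COc1ccccc1-c1ccc(-c2nnc(N(C)Cc3ccc4nccn4c3)o2)cc1` carries a 2-methoxyphenyl in the same place; in this assay compound 3 gives 1580 nM, the lower of the two numbers shown, though the gap to compound 2 is within the scatter. The measured steps are an at least 31-fold lower number from compound 1 to compound 2 (1.50 log units; beyond the scatter) and an at least 63-fold lower number from compound 1 to compound 3 (1.80 log units; beyond the scatter), both large, and a 2.0-fold lower number from compound 2 to compound 3 (0.30 log units; within the scatter).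

Compound 4 `Cc1ccccc1-c1ccc(-c2nnc(N(C)Cc3ccc4nccn4c3)o2)cc1` differs from compound 3 by methyl in place of methoxy on an aromatic carbon. The step that bears most directly on this change is the one that introduced the methoxy, a 2.0-fold lower number from compound 2 to compound 3 (0.30 log units; within the scatter), which lies within the scatter, so the methoxy itself carries no step beyond the scatter, and its replacement by methyl is expected to lie within the scatter as well. The large steps of an at least 31-fold lower number from compound 1 to compound 2 (1.50 log units; beyond the scatter) and an at least 63-fold lower number from compound 1 to compound 3 (1.80 log units; beyond the scatter) concern the aryl ring, which compound 4 keeps. Compound 4 is therefore expected to give about 1600 nM in this assay, in the range 500 nM to 5000 nM. The expected step is a 1.0-fold higher number from compound 3 to compound 4 (0.01 log units; within the scatter), none beyond the scatter.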

Compound 4, half-maximal inhibitory concentration: 631 nM
The estimate for compound 4 lay 2.5-fold (0.40 log units) above the measured number; the range from low to high includes it.
By their numbers in this assay, from the lowest: compound 4; then compounds 3 and 2 (each within the scatter of the next). At a limit, above all of these: compound 1.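

In this series, the group ortho to a large group on the outer ring can move the number beyond the scatter: methyl in place of hydrogen gives a 5.0-fold lower number from compound 2 to compound 4 (0.70 log units; beyond the scatter), and methyl in place of methoxy gives a 2.5-fold lower number from compound 3 to compound 4 (0.40 log units; beyond the scatter), whereas methoxy in place of hydrogen had given only a 2.0-fold lower number from compound 2 to compound 3 (0.30 log units; within the scatter), within the scatter. In this assay, going by these compounds alone, the identity of this small group therefore matters, and 2-methylphenyl is the first aryl change here to separate from phenyl beyond the scatter, with the full step from the unsubstituted member reading an at least 150-fold lower number from compound 1 to compound 4 (2.19 log units; beyond the scatter); compound 1 sits at a limit, which is not a number: the limit of > 100000 nM in this assay, at which 1 of the 4 values shown sits. No measured property in these notes accounts for the difference between methyl and methoxy at this place.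

The compounds shown leave open whether ethyl, isopropyl, chlorine or an amine on the same carbon would give a lower or a higher number than methyl. They also leave open what methyl would do on the other carbons of that ring, as only this one place is covered.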